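Bringing Back the Urea Nitrogen with a Cyclohexyl Ring

A few compounds are considered here, and "the series" means these few. Any claim that something is new, unique, unknown or untested is made for them only; others in the source may bear on it.

Three measured compounds share one core and differ only in the group on a carbonyl carbon that sits on a ring nitrogen. In a functional assay on CHO-K1 cells for agonist activity at Glucose-dependent insulinotropic receptor (Homo sapiens), read by a luciferase reporter, with a stated time of 5 h (a higher number here means that more compound is needed for the effect, a lower number that less compound is needed), compound 1 `CCCS(=O)(=O)N1CCN(c2ccc(OCC3CCN(C(=O)NC(C)C)CC3)cn2)CC1` gives 1000 nM. In this assay compound 2 `CCCS(=O)(=O)N1CCN(c2ccc(OCC3CCN(C(=O)NC(C)(C)C)CC3)cn2)CC1` gives 800 nM, and compound 3 `CCCS(=O)(=O)N1CCN(c2ccc(OCC3CCN(C(=O)CC(C)(C)C)CC3)cn2)CC1` gives 2800 nM. Compound 3 thus stands at the highest of the three numbers, and both steps that lead to it lie beyond the scatter.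

Compound 4 `CCCS(=O)(=O)N1CCN(c2ccc(OCC3CCN(C(=O)NC4CCCCC4)CC3)cn2)CC1` carries cyclohexylamino in place of neopentyl on a carbonyl carbon, which restores the nitrogen-bearing group that compound 1 and compound 2 have, now with a ring. For the measured compounds named here, two measured steps bear directly on this change: a 2.8-fold higher number from compound 1 to compound 3 (0.45 log units; beyond the scatter) and a 3.5-fold higher number from compound 2 to compound 3 (0.54 log units; beyond the scatter), each of which swapped such an amino group for neopentyl and raised the number modestly. Undoing that swap is expected to lower the number by a similar modest amount, a 3.1-fold lower number from compound 3 to compound 4 (0.49 log units; beyond the scatter). Compound 4 is therefore estimated at 900 nM, with a range from 400 nM to 2000 nM.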

Compound 4, half-maximal effective concentration: > 10000 nM
Compound 4: only a limit was reported; the forecaster's own chance of this, stated with the estimate: 5%; at least 11-fold (1.04 log units) between middle value and limit.
By their numbers in this assay, from the lowest: compounds 2 and 1 (each within the scatter of the next); then compound 3. At a limit, above all of these: compound 4.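

Compound 4 gives no number, only a limit: the limit of > 10000 nM in this assay, at which 1 of the 4 values shown sits. The amino group on the carbonyl carbon therefore does not lower the number by itself, since cyclohexylamino in place of neopentyl gives an at least 3.5-fold higher number from compound 3 to compound 4 (0.55 log units; beyond the scatter). What is attached to the amide-type nitrogen matters a great deal at this position: cyclohexyl in place of isopropyl gives an at least 10-fold higher number from compound 1 to compound 4 (1.00 log units; beyond the scatter), and cyclohexyl in place of tert-butyl gives an at least 12-fold higher number from compound 2 to compound 4 (1.09 log units; beyond the scatter), whereas the earlier step from isopropyl to tert-butyl stayed within the scatter.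

The compounds shown leave open whether a smaller ring on that nitrogen, such as cyclopropyl or cyclobutyl, would behave like the branched chains or like cyclohexyl. They also cannot tell how far beyond its limit compound 4 lies, so all three new steps give only minimum sizes.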